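Amide group change on the carbonyl carbon: compound 3 to compound 4

This account rests on a few compounds, and the source may have more. Where it says the series, first, only, none or still open, it means among the compounds named here.

Compound 3 `O=C(C1CC12CCC2)N1CCc2nc(C#Cc3ccccc3)sc2C1` gives the lowest number of the three measured in an assay on HEK293 cells for positive allosteric modulation of metabotropic glutamate receptor 5 (Homo sapiens), read by FLIPR, with a stated time of 1 h (on this read-out lower numbers stand for an effect already at smaller amounts and higher numbers for an effect only at larger amounts of compound), at 3.9 nM. Compound 2 `CC1CC1C(=O)N1CCc2nc(C#Cc3ccccc3)sc2C1` gives 9.4 nM in this assay, and compound 1 `O=C1NCCc2nc(C#Cc3cccc(F)c3)sc21`, which differs in the shared core and in the aryl group, gives 290 nM. For the measured compounds named here, the step of a 2.4-fold lower number from compound 2 to compound 3 (0.38 log units; beyond the scatter) is the only measured change on the carbonyl side of the shared core.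

Compound 4 `O=C(C1CCCCC1)N1CCc2nc(C#Cc3ccccc3)sc2C1` differs from compound 3 by a group of 6 heavy atoms (6 carbon; one six-membered non-aromatic ring of carbon only) in place of a group of 6 heavy atoms (6 carbon; one three-membered non-aromatic ring of carbon only, one four-membered non-aromatic ring of carbon only), on a carbonyl carbon. Going by the values given here, the one step that bears on this position, a 2.4-fold lower number from compound 2 to compound 3 (0.38 log units; beyond the scatter), shows that the number moved only modestly when the group on the carbonyl carbon was exchanged; no cyclohexyl analogue has been measured, so the direction of the present change rests on the matched heavy-atom count alone. The expected step of a 1.5-fold higher number from compound 3 to compound 4 (0.19 log units; within the scatter) is therefore small, within the scatter or slightly toward a higher number. Compound 4 is estimated at 6 nM in this assay, with a range from 2 nM to 20 nM.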

Compound 4, half-maximal effective concentration: 167 nM
The estimate for compound 4 lay 28-fold (1.44 log units) below the measured number, outside the stated range (above it).
By their numbers in this assay, from the lowest: compound 3; then compound 2; then compounds 4 and 1 (each within the scatter of the next).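

At this position the number in this assay does not follow the heavy-atom count: cyclohexyl replaces a group of equal count on the carbonyl carbon, yet the change is large (a 43-fold higher number from compound 3 to compound 4 (1.63 log units; beyond the scatter)). Cyclohexyl also compares poorly with the smaller 2-methylcyclopropyl (an 18-fold higher number from compound 2 to compound 4 (1.25 log units; beyond the scatter)), whereas the earlier exchange between two groups each holding a three-membered ring was only modest (a 2.4-fold lower number from compound 2 to compound 3 (0.38 log units; beyond the scatter)), so the group on this carbonyl carbon can move the number much further than the earlier compounds showed. No measurement at hand accounts for this change.

For the compounds shown here, with compound 2 and compound 3 the only low-number examples, it remains open whether a three-membered ring on the carbonyl carbon is what they owe their numbers to. Where cyclobutyl, cyclopentyl or an open chain such as tert-butyl would fall on this scale also remains open.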